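Switching the sulfone aryl group from methoxyphenyl to fluorophenyl

The source may hold more compounds than are shown below. What is called first, only, known or untested is meant among the compounds shown, and "the series" means these compounds.

Measured compounds:
compound 1 `O=S(=O)(c1cccc(F)c1)c1cnc2cc(Cl)ccc2c1N1CCC(CO)CC1`: 71%
compound 2 `CC1CCN(c2c(S(=O)(=O)c3ccc(Cl)cc3)cnc3cc(Cl)ccc23)CC1`: 91%
compound 3 `COc1ccc(S(=O)(=O)c2cnc3ccc(F)cc3c2N2CCC(C)CC2)cc1`: 85%

Of the compounds shown here, three have been tested in an assay on isolated protein for displacement of a labelled ligand from metabotropic glutamate receptor 5 (Homo sapiens), with a stated time of 60 min, tested at 1 uM; on this read-out higher numbers stand for more inhibition at the one concentration tested (going by the name of the read-out) and lower numbers for less inhibition. Compound 1 gives 71%, compound 2 gives 91% and compound 3 gives 85%. Compound 3 stands second highest of the three numbers; its nearest neighbour is compound 2, whose number lies within the scatter of compound 3, while compound 1 is the furthest away, with a number beyond the scatter below it. No pair among these three differs in only one place, so no single step can be read off from the measured set.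

Compound 4 `CC1CCN(c2c(S(=O)(=O)c3cccc(F)c3)cnc3ccc(F)cc23)CC1` has not yet been measured in this assay. It differs from compound 3 in one place: 3-fluorophenyl in place of 4-methoxyphenyl on a sulfonyl sulfur. Going by the values given here, the only measured compound bearing 3-fluorophenyl on the sulfonyl sulfur is compound 1, but it differs from compound 4 elsewhere as well, so its number is not a direct guide. Without any measured pair showing this change, compound 4 is expected to show a small step down, a number 5 percentage points lower from compound 3 to compound 4 (within the scatter), or none beyond the scatter. Compound 4 is therefore estimated at 80%, with a range from 65% to 92%.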

Compound 4, a percentage reported as inhibition, at one concentration (the size of the read-out at that concentration, not a potency): 76%
Estimate against measurement, compound 4: 4 percentage points above, and the stated range covers the measured number.
By their numbers in this assay, from the lowest: compounds 1, 4, 3 and 2 (each within the scatter of the next, the first and the last beyond it).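

Going by these compounds alone, compound 3 and compound 4 form the first pair in this set that differs in one place, so a change on the sulfonyl sulfur can now be read directly in this assay. Putting 3-fluorophenyl in place of 4-methoxyphenyl gives a number 9 percentage points lower from compound 3 to compound 4 (within the scatter), which shows that, on this core and at the one concentration tested, this exchange produces no step beyond the scatter. Nothing available explains this result.

The compounds shown leave open whether the same exchange would behave alike on the core of compound 1 or compound 2, since a single pair cannot show that. They also leave open how an aminophenyl group or a benzoic acid group would fare on the sulfonyl sulfur, and how potency would compare across these compounds.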